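A few compounds are considered here, and "the series" means these few. Any claim that something is new, unique, unknown or untested is made for them only; others in the source may bear on it.

Measured compounds:
compound 1 `C=CC(C)(C/C=C(\C)CCC=C(C)C)c1ccc(O)c(O)c1` gives 12.2 ug/mL in a functional assay on HCT-8 cells (Homo sapiens) for cytotoxicity, read by MTT assay, with a stated time of 72 h; on this read-out higher numbers stand for weaker inhibition and lower numbers for stronger inhibition
compound 2 `C=CC(C)(C/C=C(\C)CCC=C(C)C)c1ccc(O)c(OC)c1` gives 14.5 ug/mL in this assay

Compound 1 stands at one end of these two numbers, and compound 2 sits within the scatter of it. Compound 3 `C=CC(C)(C/C=C(\C)CCC=C(C)C)c1ccc(OC)c(O)c1` differs from compound 1 by methyl in place of hydrogen on an oxygen on an aromatic ring. For the measured compounds named here, the only measured step that bears on this change is a 1.2-fold higher number from compound 1 to compound 2 (0.08 log units; within the scatter), the same kind of methylation on an oxygen on an aromatic ring, and it stayed within the scatter. For compound 3 the expected step is therefore a 1.1-fold higher number from compound 1 to compound 3 (0.06 log units; within the scatter), nothing beyond the scatter. Compound 3 is estimated at 14 ug/mL, with a range from 8 ug/mL to 25 ug/mL.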

Compound 3, half-maximal inhibitory concentration: > 25 ug/mL
Compound 3: only a limit was reported; the forecaster's own chance of this, stated with the estimate: 5%; middle value at least 1.7-fold (0.25 log units) away from the limit.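

Compound 3 is reported only as a limit, > 25 ug/mL in this assay. Even so, hydroxy to methoxy here gives an at least 2.0-fold higher number from compound 1 to compound 3 (0.31 log units; beyond the scatter), which means weaker inhibition, whereas the same change on the other oxygen gave a 1.2-fold higher number from compound 1 to compound 2 (0.08 log units; within the scatter). Among these compounds, then, the outcome of adding the methyl depends on which oxygen on the aromatic ring carries it.

Going by these compounds, how far the true value of compound 3 lies from that limit stays open. So does what a longer chain on this oxygen, or an amine in place of the hydroxy, would do.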